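Adding a Bromo to Compound 2

The source may report more compounds than this note shows. Statements on the series, on what has been measured and on what is new or still open speak of the compounds shown alone.

Within the data shown here, in a functional assay on MCF7 cells (Homo sapiens) for cytotoxicity, read by MTT assay, with a stated time of 48 h (on this read-out higher numbers stand for weaker inhibition and lower numbers for stronger inhibition), compound 2 `COc1cc(-c2ocnc2-c2cc(OC)c(OC)c(OC)c2)ccc1SC` gives 600 nM, the lowest number so far. Compound 1 `COc1cc(-c2ocnc2-c2cc(Br)c(OC)c(OC)c2)ccc1SC` gives 2480 nM and compound 3 `COc1ccc(-c2c(-c3cc(Br)c(OC)c(OC)c3)ncn2C)cc1SC` gives 5240 nM, and the gaps from both of them to compound 2 lie clearly outside the scatter. Compound 4 `COc1cc(-c2ncoc2-c2cc(Br)c(SC)c(OC)c2)cc(OC)c1OC` differs from compound 2 by one change, bromo in place of hydrogen on an aromatic carbon, ortho to a methylsulfanyl group. Among the measured compounds shown here, only one measured step involves bromo: a 4.1-fold lower number from compound 1 to compound 2 (0.62 log units; beyond the scatter), a modest step with methoxy in place of bromo. For the measured compounds named here, that step replaced no hydrogen, so it is only a loose guide, and no measured step shows this exact change. A modest rise in this assay is therefore expected, and the expected step is a 2.5-fold higher number from compound 2 to compound 4 (0.40 log units; beyond the scatter). Compound 4 is estimated at 1500 nM, with an expected range from 300 nM to 6000 nM.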

Compound 4, half-maximal inhibitory concentration: 1420 nM
Beside the measured number, compound 4's estimate is 1.1-fold (0.02 log units) above it, and the stated range covers the measured number.
By their numbers in this assay, from the lowest: compound 2; then compounds 4 and 1 (each within the scatter of the next); then compound 3.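

In this assay, putting bromo in place of hydrogen on an aromatic carbon, ortho to a methylsulfanyl group, gives a 2.4-fold higher number from compound 2 to compound 4 (0.37 log units; beyond the scatter), a real but modest loss. The earlier compounds shown here showed bromo only as an exchange with methoxy, whereas this is a direct measure of adding it to compound 2. Nothing measured here explains this rise.

From the compounds shown here alone, it remains open whether an amine or a carboxylic acid on this same carbon would keep the number near that of compound 2. The effect of a chlorine or fluorine atom there is also unknown.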